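A few compounds are considered here, and "the series" means these few. Any claim that something is new, unique, unknown or untested is made for them only; others in the source may bear on it.

In a functional assay on HCT-116 cells (Homo sapiens) for cytotoxicity, read by MTT assay, with a stated time of 72 h (on this read-out lower numbers stand for stronger inhibition and higher numbers for weaker inhibition), compound 1 `Nc1cccc(Nc2nc3ccccc3nc2S(=O)(=O)c2ccccc2)c1` gives 1540 nM, compound 2 `COc1ccc(S(=O)(=O)c2nc3ccccc3nc2Nc2cccc(N)c2)cc1` gives 3710 nM, and compound 3 `Nc1ccc(Nc2nc3ccccc3nc2S(=O)(=O)c2ccc(F)cc2)cc1` gives 10100 nM, the highest of the three numbers and beyond the scatter from both others. Compound 4 `Nc1cccc(Nc2nc3ccccc3nc2S(=O)(=O)c2ccc(F)cc2)c1` differs from compound 3 as follows: 3-aminophenyl in place of 4-aminophenyl on a nitrogen on an aromatic ring. Among the compounds with values here, no measured step makes this change. The only one, a 2.4-fold higher number from compound 1 to compound 2 (0.38 log units; beyond the scatter), is a different change and modest in size. Still, compound 1 at 1540 nM and compound 2 at 3710 nM both carry the 3-aminophenyl that compound 4 gains, and both lie lower than compound 3. A moderate step to a lower number is therefore expected, a 4.0-fold lower number from compound 3 to compound 4 (0.61 log units; beyond the scatter). The estimate for compound 4 is 2500 nM, with an expected range from 900 nM to 7000 nM.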

Compound 4, half-maximal inhibitory concentration: 6790 nM
Beside the measured number, compound 4's estimate is 2.7-fold (0.43 log units) below it; low and high end bracket the measured number.
By their numbers in this assay, from the lowest: compound 1; then compounds 2, 4 and 3 (each within the scatter of the next, the first and the last beyond it).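

In this assay, 3-aminophenyl in place of 4-aminophenyl on this nitrogen gives a 1.5-fold lower number from compound 3 to compound 4 (0.17 log units; within the scatter), so with the fluoro group kept, this swap does not separate the two compounds. Fluoro in place of methoxy gives a 1.8-fold higher number from compound 2 to compound 4 (0.26 log units; within the scatter), whereas fluoro in place of hydrogen gives a 4.4-fold higher number from compound 1 to compound 4 (0.64 log units; beyond the scatter), making hydrogen to fluoro the only one of these steps beyond the scatter.

Going by these compounds, whether the aminophenyl swap would behave alike with hydrogen or methoxy in place of fluoro stays open, as does the effect of a carboxylic acid in place of the amine. Nothing available explains these steps.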